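This account rests on a few compounds, and the source may have more. Where it says the series, first, only, none or still open, it means among the compounds named here.

Measured compounds in a functional assay on MCF7 cells (Homo sapiens) for antiproliferative activity, read by MTT assay, with a stated time of 72 h; a higher number here means a weaker inhibitor, a lower number a stronger inhibitor:

Compound 1 `Cc1ccccc1NC1=C/C(=N/NC(N)=S)C(=O)N=C1Nc1ccccc1C` gives 580 nM.
Compound 2 `Cc1cccc(NC2=C/C(=N/NC(N)=S)C(=O)N=C2Nc2cccc(C)c2)c1` gives 150 nM.
Compound 3 `Cc1ccccc1NC1=C/C(=N/N=C(\N)SCc2ccccc2)C(=O)N=C1Nc1ccccc1C` gives 16300 nM.

Compound 1 and compound 2 share the same atoms joined differently; the difference between the two cores is not broken down here. Going from compound 1 to compound 3, the change is a group of 11 heavy atoms (8 carbon, 2 nitrogen, 1 sulfur; one six-membered aromatic ring of carbon only) in place of a group of 4 heavy atoms (1 carbon, 2 nitrogen, 1 sulfur; no ring), on a double-bonded nitrogen, and the step in this assay is a 28-fold higher number from compound 1 to compound 3 (1.45 log units; beyond the scatter). The unmeasured compound 4 `Cc1cccc(NC2=C/C(=N/N=C(\N)SCc3ccccc3)C(=O)N=C2Nc2cccc(C)c2)c1` carries the same change on the core of compound 2: a group of 11 heavy atoms (8 carbon, 2 nitrogen, 1 sulfur; one six-membered aromatic ring of carbon only) in place of a group of 4 heavy atoms (1 carbon, 2 nitrogen, 1 sulfur; no ring), on a double-bonded nitrogen. Because the step of a 28-fold higher number from compound 1 to compound 3 (1.45 log units; beyond the scatter) was large, a step of similar size is expected for compound 4, estimated as a 27-fold higher number from compound 2 to compound 4 (1.43 log units; beyond the scatter). For compound 4 the expected value in this assay is 4000 nM, estimated to lie between 1000 nM and 16000 nM.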

Compound 4, half-maximal inhibitory concentration: 9340 nM
Beside the measured number, compound 4's estimate is 2.3-fold (0.37 log units) below it; the measured number falls inside the stated range.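

In this assay, the same change on the core of compound 2 again gives a large step (a 62-fold higher number from compound 2 to compound 4 (1.79 log units; beyond the scatter)), so the number rises on both cores. The sizes of the two steps agree: the same change on two cores in this assay, a 28-fold higher number (1.45 log units; beyond the scatter) from compound 1 to compound 3 and a 62-fold higher number (1.79 log units; beyond the scatter) from compound 2 to compound 4, 2.2-fold (0.35 log units) apart, within the scatter of two such steps. This shows that the change carried over from one core to the other with a similar size, but two cores cannot show that it would do so on others, and these numbers do not explain why the compounds weaken.

From the compounds shown here alone, it remains open which part of the entering group matters. A version with a methyl in place of its six-membered aromatic ring, or with an amine on that ring, could give a different step.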